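This account rests on a few compounds, and the source may have more. Where it says the series, first, only, none or still open, it means among the compounds named here.

Measured compounds:
compound 1, `CCCCc1cn(C(c2ccccc2)c2cc3cc(Br)ccc3nc2OC)nn1` — 11.1%
compound 2, `CCCCCCCCc1cn(C(c2ccccc2)c2cc3cc(Br)ccc3nc2OC)nn1` — 2.06%

In an ADME assay on SK-OV-3 cells (Homo sapiens) for cytotoxicity, read by sulforhodamine B assay, with a stated time of 48 h, tested at 10 uM (on this read-out lower numbers stand for less inhibition and higher numbers for more inhibition at the one concentration tested (going by the name of the read-out)), compound 2 gives 2.06%, the lower of the two numbers shown, and its only neighbour, compound 1, gives 11.1%, a gap that lies within the scatter. For the measured compounds named here, the one measured step, a number 9 percentage points lower from compound 1 to compound 2 (within the scatter), lengthened a chain on the shared core and moved the read-out by an amount no larger than repeated measurements of this kind would show on their own.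

Compound 3, `COc1nc2ccc(Br)cc2cc1C(c1ccccc1)n1cc(C2CC2)nn1`, is not yet measured. It differs from compound 2 in one place: cyclopropyl in place of octyl on an aromatic carbon. Going by the values given here, the measured step also changed the group on that same aromatic carbon, so it is the only step that bears on this change, and it stayed within the scatter. No step beyond the scatter is therefore expected in this assay for compound 3, which is estimated at 8% (range -6% to 22%), an expected step of a number 5.9 percentage points higher from compound 2 to compound 3 (within the scatter).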

Compound 3, a percentage reported as inhibition, at one concentration (the size of the read-out at that concentration, not a potency): 3.52%
Estimate against measurement, compound 3: 4.5 percentage points above; measured number inside the range.
By their numbers in this assay, from the lowest: compounds 2, 3 and 1 (each within the scatter of the next).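

In this assay, cyclopropyl in place of octyl on this aromatic carbon gives a number 1.5 percentage points higher from compound 2 to compound 3 (within the scatter), and cyclopropyl in place of butyl gives a number 7.6 percentage points lower from compound 1 to compound 3 (within the scatter). The position has now carried a small ring as well as two open chains, and no pair among these three compounds differs by more than the scatter, so the read-out does not separate these groups. No other measurement bears on this result.

Going by these compounds, what an amine or a carboxylic acid on this aromatic carbon would give stays open, as does whether any group there can move the number beyond the scatter. On these data alone, all three compounds also share the rest of the core, so the effect of changing another part of it remains unknown.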